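One Stereocentre Changed in Compound 1

The compounds below may be only part of what the source reports. "The series", "measured", "known", "first", "only" and "open" are said of these compounds alone.

In a functional assay on QGY cells (Homo sapiens) for cytotoxicity, read by MTT assay, with a stated time of 48 h (on this read-out higher numbers stand for weaker inhibition and lower numbers for stronger inhibition), compound 1 (`COc1cc([C@@H]2C[C@]2(CO)C(=O)Nc2ccccc2Cl)cc(OC)c1OC`) gives 15700 nM. Compound 2 (`COc1cc([C@@H]2C[C@]2(CO)C(=O)NCc2ccc(C)cc2)cc(OC)c1OC`), which carries 4-methylbenzyl in place of 2-chlorophenyl on an amide-type nitrogen, gives 25100 nM in this assay. Going by the values given here, the only measured comparison is therefore a 1.6-fold higher number from compound 1 to compound 2 (0.20 log units; within the scatter), so compound 1 does not stand apart from its one neighbour.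

Compound 3 (`COc1cc([C@H]2C[C@]2(CO)C(=O)Nc2ccccc2Cl)cc(OC)c1OC`) is the next to be considered. The change from compound 1 is the two compounds have the same atoms and bonds and differ only in configuration as drawn: 1 of 2 stereo elements differ; a stereocentre at a saturated ring carbon is drawn S in compound 1 and R in compound 3: a stereocentre at a saturated ring carbon is drawn S in compound 1 and R in compound 3, and the two compounds have the same atoms and bonds.

The measured step bears on this only loosely, since it alters the amide-type nitrogen substituent and leaves the configuration as drawn untouched. Among the compounds with values here, no measured pair shows what a change of configuration does here, so the data give no direction. The expected result is a 1.1-fold higher number from compound 1 to compound 3 (0.06 log units; within the scatter), with no step beyond the scatter anticipated, though with real uncertainty. For compound 3 the estimated value is 18000 nM, with an expected range from 6000 nM to 50000 nM.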

Compound 3, half-maximal inhibitory concentration: 40700 nM
The estimate for compound 3 lay 2.3-fold (0.35 log units) below the measured number; the range from low to high includes it.
By their numbers in this assay, from the lowest: compounds 1, 2 and 3 (each within the scatter of the next, the first and the last beyond it).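

Going by these compounds alone, compound 3 gives the first step in this set that lies beyond the scatter, and it comes from configuration rather than from a substituent: a 2.6-fold higher number from compound 1 to compound 3 (0.41 log units; beyond the scatter). The earlier step changed the group on the amide-type nitrogen and stayed within the scatter, so it gave no sign that anything in this assay responded to structure; this pair shows that the saturated ring carbon does respond, modestly, with the form drawn S giving the lower number and so the stronger inhibition. The step can be assigned to that single stereocentre, and to no change of groups, because nothing else separates the pair: the fact that compounds 1 and 3 differ only in the configuration as drawn

The compounds shown leave open whether the same preference holds with 4-methylbenzyl on the amide-type nitrogen, since only the 2-chlorophenyl compounds form a pair at this ring carbon, and what changing the other stereo element, which stays the same in compound 1 and compound 3, would do. They also leave open whether a longer alkyl chain or a carboxylic acid on the amide-type nitrogen would move the number beyond the scatter.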